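This account rests on a few compounds, and the source may have more. Where it says the series, first, only, none or still open, it means among the compounds named here.

Of the compounds shown here, three have been tested so far in a functional assay on HCT-116 cells (Homo sapiens) for inhibition, read by sulforhodamine B assay, with a stated time of 48 h, tested at 50 uM; on this read-out higher numbers stand for more inhibition of growth at the one concentration tested and lower numbers for less inhibition of growth. Compound 1 `COc1cc(/C=C/C(=O)/C=C/c2cccc3ccccc23)ccc1OCc1cn(CCCOc2cc(=O)oc3ccccc23)nn1` gives 66%. Compound 2 `COc1ccc(/C=C/C(=O)/C=C/c2ccc(OCc3cn(CCCCOc4cc(=O)oc5ccccc45)nn3)c(OC)c2)cc1OC` gives 55%. Compound 3 `COc1ccc(/C=C/C(=O)/C=C/c2ccc(OCc3cn(CCCCCOc4cc(=O)oc5ccccc45)nn3)c(OC)c2)cc1OC` gives 45%, a value within the usual scatter of compound 2 and beneath compound 1 by a gap beyond that scatter.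

Compound 4 `COc1cccc(/C=C/C(=O)/C=C/c2ccc(OCc3cn(CCCCCOc4cc(=O)oc5ccccc45)nn3)c(OC)c2)c1` has not been measured yet. It differs from compound 3 in one place: hydrogen in place of methoxy on an aromatic carbon. In words, this is hydrogen in place of methoxy on an aromatic carbon, so that 3,4-dimethoxyphenyl becomes 3-methoxyphenyl. Going by the values given here, no two measured compounds differ in only one place, so the data hold no direct precedent for this change. With nothing pointing either way, no step beyond the scatter is expected in this assay. The expected size of the change, a number 3 percentage points higher from compound 3 to compound 4 (within the scatter), is therefore small and its direction uncertain. For compound 4 the estimated value is 48%, with an expected range of 33% to 62%.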

Compound 4, percent growth inhibition at one concentration: 36%
Estimate against measurement, compound 4: 12 percentage points above, within the range that was stated.
By their numbers in this assay, from the lowest: compounds 4, 3 and 2 (each within the scatter of the next, the first and the last beyond it); then compound 1.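

Going by these compounds alone, compound 3 and compound 4 are the first pair that differ in one place only, so they give the first direct reading of a change on this ring. In this assay, going from 3,4-dimethoxyphenyl to 3-methoxyphenyl gives a number 9 percentage points lower from compound 3 to compound 4 (within the scatter), so the two compounds cannot be told apart and this methoxy is not shown to matter for growth inhibition with the rest of compound 3 kept. Nothing at hand explains this reading.

The compounds shown leave open whether another group at this place, such as an amine or a carboxylic acid, would give a step beyond the usual scatter. They also leave open whether removing this methoxy reads the same with a longer chain in the linker.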